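The source may hold more compounds than are shown below. What is called first, only, known or untested is meant among the compounds shown, and "the series" means these compounds.

Compound 1 `COc1ccc(/C=C2\CN(C)C/C(=C\c3ccncc3)C2=O)c(OC)c1OC`: 15600 nM
Compound 2 `Cc1ccc(S(=O)(=O)N2C/C(=C\c3cccnc3)C(=O)/C(=C/c3ccccc3F)C2)cc1`: 14900 nM
Compound 3 `Cc1ccc(S(=O)(=O)N2C/C(=C\c3ccncc3)C(=O)/C(=C/c3ccccc3F)C2)cc1`: > 20000 nM

These values come from an ADME assay on L02 cells (Homo sapiens) for cytotoxicity, read by MTT assay, with a stated time of 24 h; a lower number here means a stronger inhibitor, a higher number a weaker inhibitor. Compound 3 stands at > 20000 nM, which is a limit and not a number. Compound 4 `N#Cc1ccc(S(=O)(=O)N2C/C(=C\c3ccncc3)C(=O)/C(=C/c3ccccc3F)C2)cc1` differs from compound 3 in one place: cyano in place of methyl on an aromatic carbon. Going by the values given here, the only measured step is an at least 1.3-fold higher number from compound 2 to compound 3 (0.12 log units; that floor lies within the scatter). It swaps pyridin-3-yl for pyridin-4-yl and leaves the methyl untouched, so it bears only indirectly. Among the compounds with values here, no measured step tests the new group, so no change beyond the scatter is expected in this assay, and no clear direction. Compound 4 is expected at 18000 nM, with an estimated range of 9000 nM to 30000 nM. This estimate means an expected at least 1.1-fold lower number from compound 3 to compound 4 (0.04 log units; that floor lies within the scatter).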

Compound 4, half-maximal inhibitory concentration: > 20000 nM
Compound 4 gave a limit, no number; the forecaster's own chance of this, stated with the estimate: 45%; middle value at least 1.1-fold (0.04 log units) away from the limit.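

No new step can be read between compound 3 and compound 4, because each gives only a limit of the assay and not a number: the limit of > 20000 nM in this assay, at which 2 of the 4 values shown sit. From the compounds shown here alone, whether cyano in place of methyl changes the reading at all stays open.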